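A few compounds are considered here, and "the series" means these few. Any claim that something is new, unique, unknown or untested is made for them only; others in the source may bear on it.

Within the data shown here, compound 2 `Cc1ccc(NC2=C(C(=O)c3ccccc3)C(c3ccc(Br)cc3)N(CCCn3ccnc3)C2=O)cc1` is one of two compounds measured in a functional assay on A549 cells (Homo sapiens) for antiproliferative activity, read by MTT assay, with a stated time of 72 h (a higher number here means a weaker inhibitor, a lower number a stronger inhibitor), where compound 2 gives 29400 nM. Its only companion, compound 1 `O=C(C1=C(OC2CCCCC2)C(=O)N(CCCn2ccnc2)C1c1ccc(Br)cc1)c1ccccc1`, gives 31200 nM in this assay, and the step of a 1.1-fold lower number from compound 1 to compound 2 (0.03 log units; within the scatter) shows that the two numbers sit within the scatter of each other; compound 2 holds the lower of the two numbers, but no order between them can be claimed. The step now taken leads to compound 3 `O=C(C1=C(Nc2ccc(Cl)cc2)C(=O)N(CCCn2ccnc2)C1c1ccc(Br)cc1)c1ccccc1`, with the change (chloro in place of methyl on an aromatic carbon). Among the measured compounds shown here, no measured step touches this place: the only known step, from compound 1 to compound 2, changed the whole group on the double-bonded ring carbon and stayed within the scatter. With nothing pointing either way, compound 3 is expected to stand near compound 2, the step of a 1.0-fold lower number from compound 2 to compound 3 (0.01 log units; within the scatter) being expected to lie within the scatter. Compound 3 is therefore estimated at 29000 nM, within a range from 12000 nM to 70000 nM.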

Compound 3, half-maximal inhibitory concentration: 30000 nM
The estimate for compound 3 lay 1.0-fold (0.01 log units) below the measured number; the measured number falls inside the stated range.
By their numbers in this assay, from the lowest: compounds 2, 3 and 1 (each within the scatter of the next).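

In this assay, among these compounds, the swap of chloro for methyl on an aromatic carbon, para to a large group, gives a 1.0-fold higher number from compound 2 to compound 3 (0.01 log units; within the scatter) and so offers the first reading at this position, where the two groups cannot be told apart. The step of a 1.0-fold lower number from compound 1 to compound 3 (0.02 log units; within the scatter) comes with (4-chlorophenyl)amino in place of cyclohexyloxy on the double-bonded ring carbon, so this second amino group also cannot be separated from cyclohexyloxy. No measured evidence accompanies these results to account for them. The compounds shown leave open whether a methoxy group, an amine or a carboxylic acid on that aromatic carbon would stand apart from methyl and chloro. They also leave open whether a morpholine or a plain alkylamine on the double-bonded ring carbon would move the number beyond the scatter.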